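Second chloro on the shared core of compound 2

The compounds below may be only part of what the source reports. "The series", "measured", "known", "first", "only" and "open" are said of these compounds alone.

Compound 2 `C[C@@H](NC(=O)Nc1ccccc1Cl)c1ccccc1` gives in an ADME assay on the whole organism with Oryza sativa as the target, tested at 0.1 uM (on this read-out lower numbers stand for a stronger effect and higher numbers for a weaker effect at the one concentration tested), a value of 101%. It stands level with compound 1 `CCc1ccccc1NC(=O)N[C@H](C)c1ccccc1`, which gives 101%; together these are the highest of the three numbers, and the step of no change at the digits printed from compound 1 to compound 2 (within the scatter) lies within the scatter. Compound 3 `C[C@@H](NC(=O)Nc1cc(Cl)ccc1Cl)c1ccccc1` gives 99%, and the step of a number 2 percentage points lower from compound 2 to compound 3 (within the scatter) also stays within the scatter.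

Compound 4 `C[C@@H](NC(=O)Nc1c(Cl)cccc1Cl)c1ccccc1` is not yet measured. It differs from compound 2 by chloro in place of hydrogen on an aromatic carbon. Among the measured compounds shown here, the one measured step of the same kind, a number 2 percentage points lower from compound 2 to compound 3 (within the scatter), bears on it and was within the scatter; the step of no change at the digits printed from compound 1 to compound 2 (within the scatter) likewise showed no change. None of the three measured compounds moves beyond the scatter in this assay. For compound 4 the expected step is therefore a number 1 percentage points lower from compound 2 to compound 4 (within the scatter), none beyond the scatter. Compound 4 is estimated at 100% in this assay, with a range from 90% to 108%.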

Compound 4, a percentage reported as activity, at one concentration (the size of the read-out at that concentration, not a potency): 100%
Compound 4: the middle estimate sits on the measured number at the digits printed, and the stated range covers the measured number.
By their numbers in this assay, from the lowest: compounds 3, 4, 1 and 2 (each within the scatter of the next).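

With chloro on an aromatic carbon ortho to a large group and meta to a chloro group, this assay gives a number 1 percentage points lower from compound 2 to compound 4 (within the scatter) and stays level with the rest of the series. This adds a second placement of the same change on the shared core of compound 2, alongside a number 2 percentage points lower from compound 2 to compound 3 (within the scatter) as the earlier step. Across these two placements, chloro in place of hydrogen produces no step beyond the scatter, and no data here offer an explanation for that flat response.

As far as these compounds go, whether an amine or a carboxylic acid on this aromatic ring would move the read-out beyond the scatter remains open. So does the effect of a longer chain in place of the methyl group on the shared core.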